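The source may report more compounds than this note shows. Statements on the series, on what has been measured and on what is new or still open speak of the compounds shown alone.

Notes on the series. Compound 1 `COc1cc2c(Oc3ccc(NC(=O)c4cc(-c5ccccc5)ccn4)cc3F)ccnc2cc1OCCCN1CCCCC1` gives 1800 nM in a functional assay on A549 cells (Homo sapiens) for cytotoxicity, read by MTT assay, with a stated time of 72 h; on this read-out lower numbers stand for stronger inhibition and higher numbers for weaker inhibition. Compound 2 `COc1cc2c(Oc3ccc(NC(=O)c4nccc(-c5ccccc5)n4)cc3F)ccnc2cc1OCCCN1CCCCC1` has "not determined" (no result reported) in this assay, so compound 2 stands on no number of its own. Compound 3 `COc1cc2c(Oc3ccc(NC(=O)c4nccc(-c5ccc(C)cc5)n4)cc3F)ccnc2cc1OCCCN1CCCCC1` differs from compound 2 by methyl in place of hydrogen on an aromatic carbon. For the measured compounds named here, no measured pair shows this change, so the step from compound 2 to compound 3 in this assay is expected to be small, in no settled direction, and probably within the scatter. Compound 1 at 1800 nM is the nearest anchor. The value of compound 3 in this assay is estimated at 2000 nM, within 600 nM to 6500 nM.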

Compound 3, half-maximal inhibitory concentration: 900 nM
Beside the measured number, compound 3's estimate is 2.2-fold (0.35 log units) above it; low and high end bracket the measured number.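

In this assay no step can be read between compound 2 and compound 3; compound 2 carries no number. The compounds shown leave open what phenyl to 4-methylphenyl does to the value, and no other data bear on this result.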